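The compounds below may be only part of what the source reports. "The series", "measured", "known", "first", "only" and "open" are said of these compounds alone.

Among the compounds with values here, the three compounds measured so far share one core and differ only in the group on the carbon with a double bond to nitrogen. In a functional assay on UACC-62 cells (Homo sapiens) for inhibition, read by sulforhodamine B assay, with a stated time of 48 h (a lower number here means a stronger inhibitor of growth, a higher number a weaker inhibitor of growth), compound 1 `CC1=CC[C@H](C(C)(C)NC(=S)N/N=C/c2ccccc2)CC1` gives 31600 nM. Compound 2 `CC1=CC[C@H](C(C)(C)NC(=S)N/N=C/c2ccccc2Cl)CC1` gives 19300 nM in this assay. Compound 3 `CC1=CC[C@H](C(C)(C)NC(=S)N/N=C/c2ccc[nH]2)CC1` gives 14800 nM in this assay, the lowest of the three numbers; its nearest neighbour is compound 2, while the gap to compound 1 is wider. The two steps leading to compound 3 are a 2.1-fold lower number from compound 1 to compound 3 (0.33 log units; beyond the scatter) and a 1.3-fold lower number from compound 2 to compound 3 (0.12 log units; within the scatter), both of them exchanges of the group on that carbon, and neither large.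

Compound 4 `CC1=CC[C@H](C(C)(C)NC(=S)N/N=C/c2cccs2)CC1` is not yet measured. It differs from compound 3 in one place: thiophen-2-yl in place of 1H-pyrrol-2-yl on a carbon with a double bond to nitrogen. Within the data shown here, no measured pair shows this particular exchange, so the only guide is that the swaps already seen at this carbon moved the number modestly or not at all. On that basis compound 4 is expected to show a step of a 1.1-fold higher number from compound 3 to compound 4 (0.03 log units; within the scatter) in this assay, not beyond the scatter. The estimate for compound 4 in this assay is 16000 nM, with a range from 7000 nM to 36000 nM.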

Compound 4, concentration for 50% growth inhibition: 2600 nM
The estimate for compound 4 lay 6.2-fold (0.79 log units) above the measured number; measured number outside the range, below it.
By their numbers in this assay, from the lowest: compound 4; then compounds 3, 2 and 1 (each within the scatter of the next, the first and the last beyond it).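

With thiophen-2-yl in place of 1H-pyrrol-2-yl, this assay shows (a 5.7-fold lower number from compound 3 to compound 4 (0.76 log units; beyond the scatter)) that this carbon with a double bond to nitrogen tolerates more than small shifts, even though the two groups have the same count of heavy atoms and each is one five-membered aromatic ring with 1 hetero atom; they differ in that hetero atom, sulfur for nitrogen, and in the hydrogen-bond donor and acceptor counts. Within the data shown here, compound 4 also separates from the six-membered aromatic groups (a 7.4-fold lower number from compound 2 to compound 4 (0.87 log units; beyond the scatter); a 12-fold lower number from compound 1 to compound 4 (1.08 log units; beyond the scatter)), so that all three of its steps lie beyond the scatter, it has the lowest number of the set, and the exchange from phenyl is the only large step seen at this carbon. Nothing given here accounts for the size of this change, and the counted differences between the two groups remain a description rather than an explanation.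

The compounds shown leave open whether furan-2-yl, with oxygen as its hetero atom, would follow thiophen-2-yl or 1H-pyrrol-2-yl, and whether a methyl group or a bromine on the thiophene ring would keep the low number. They also leave open whether the gain would persist on a core other than the shared one.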